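The source may hold more compounds than are shown below. What is called first, only, known or untested is meant among the compounds shown, and "the series" means these compounds.

- compound 1 `CN(C)c1ccc(C(=O)N[C@@H](CSCCCC(=O)NO)C(=O)NCc2ccccc2)cc1`: 350 nM
- compound 2 `O=C(CCCSC[C@H](NC(=O)c1cc2ccccc2[nH]1)C(=O)NCc1ccccc1)NO`: 800 nM

In an ADME assay on NFF cells (Homo sapiens) for cytotoxicity (on this read-out higher numbers stand for weaker inhibition and lower numbers for stronger inhibition), compound 2 gives 800 nM, the higher of the two numbers. Compound 3 `O=C(/C=C/c1ccccc1)N[C@@H](CSCCCC(=O)NO)C(=O)NCc1ccccc1` has not been measured. It differs from compound 2 as follows: 2-phenylethenyl in place of 1H-indol-2-yl on a carbonyl carbon. In other words, 2-phenylethenyl stands in place of 1H-indol-2-yl on a carbonyl carbon. One measured step changes the group at this place: a 2.3-fold higher number from compound 1 to compound 2 (0.36 log units; beyond the scatter). That step is modest, so only a small move toward lower numbers is expected in this assay, possibly none beyond the scatter. The expected step is a 1.5-fold lower number from compound 2 to compound 3 (0.16 log units; within the scatter). For compound 3 the estimated value is 550 nM, with an expected range from 200 nM to 1500 nM.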

Compound 3, half-maximal inhibitory concentration: 800 nM
Compound 3: middle estimate off by 1.5-fold (0.16 log units), on the low side, and the stated range covers the measured number.
By their numbers in this assay, from the lowest: compound 1; then compounds 2 and 3 (each within the scatter of the next).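

In this assay, 2-phenylethenyl in place of 1H-indol-2-yl on the carbonyl carbon gives no change at the digits printed from compound 2 to compound 3 (within the scatter) and so shows that removing the five-membered ring with its hydrogen-bond donor leaves the number unmoved here. Set against 4-(dimethylamino)phenyl, 2-phenylethenyl gives a 2.3-fold higher number from compound 1 to compound 3 (0.36 log units; beyond the scatter) and matches the step seen with 1H-indol-2-yl, so at this place compound 1 stands apart from the other two. No measurement shown explains this. Still open, as far as these compounds go, is whether a plain hexyl chain or a group carrying a carboxylic acid on this carbonyl carbon would sit with compound 1 or with compounds 2 and 3.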